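A few compounds are considered here, and "the series" means these few. Any claim that something is new, unique, unknown or untested is made for them only; others in the source may bear on it.

Working notes on an ADME assay on H9c2 cells (Rattus norvegicus) for cytotoxicity, read by resazurin assay, with a stated time of 72 h; a lower number here means that less compound is tolerated, a higher number that more compound is tolerated. Compound 1 `C/C(=N\Nc1nc(CCl)cs1)c1ccc(Cl)c(Cl)c1` gives > 50000 nM, which is a limit and not a number. Compound 2 `C/C(=N\Nc1nc(-c2ccncc2)cs1)c1ccc(Cl)c(Cl)c1` reads 41900 nM. Compound 3 `C/C(=N\Nc1nc(-c2ccc(C)cc2)cs1)c1ccc(Cl)c(Cl)c1` gives > 50000 nM, which is also only a limit, so its position is known from one side alone.

The next change leads to compound 4 `C/C(=N\Nc1nc(-c2ccc(Cl)cc2Cl)cs1)c1ccc(Cl)c(Cl)c1`: 2,4-dichlorophenyl in place of 4-methylphenyl on an aromatic carbon. In words, 2,4-dichlorophenyl replaces 4-methylphenyl on an aromatic carbon.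

Three measured exchanges at this same carbon bear on it: an at least 1.1-fold lower number from compound 1 to compound 2 (0.07 log units; that floor lies within the scatter), an at least 1.1-fold higher number from compound 2 to compound 3 (0.07 log units; that floor lies within the scatter) and a step that the two limits leave unreadable from compound 1 to compound 3. The first two show no size beyond the scatter, and the third has no readable size. None of them tests 2,4-dichlorophenyl. No step beyond the scatter is therefore expected in this assay, and any movement is expected to be slightly towards a lower number. The expectation stays high because of the limit of > 50000 nM in this assay, at which 2 of the 3 values shown sit. A further limit would fit equally well.

The estimated change is an at least 1.2-fold lower number from compound 3 to compound 4 (0.09 log units; that floor lies within the scatter). For compound 4 the expected value is 40000 nM, with an estimated range of 18000 nM to 50000 nM.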

Compound 4, half-maximal cytotoxic concentration: > 50000 nM
Compound 4: a limit, no number; the forecaster's own chance of this, stated with the estimate: 50%; middle value at least 1.2-fold (0.09 log units) from the limit.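

In this assay compound 4 gives > 50000 nM, which is a limit and not a number. At this carbon, next to the ring nitrogen, 2,4-dichlorophenyl thus joins 4-methylphenyl and chloromethyl at the limit; the steps among these three cannot be read, and the one readable step is an at least 1.1-fold higher number from compound 2 to compound 4 (0.07 log units; that floor lies within the scatter). A second chlorine-bearing group on this carbon therefore adds no separation within the series, and the groups remain unresolved because the read-out stops at the same ceiling: the limit of > 50000 nM in this assay, at which 3 of the 4 values shown sit.

Open, as far as these compounds go, is whether an aminomethyl group or a carboxylic acid on this carbon would give a number clear of the limit and beyond the scatter. Every exchange shown falls at this one carbon, and the effect of a change elsewhere on the shared core remains unknown.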